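Trading a ring amine for an open-chain amine

A few compounds are considered here, and "the series" means these few. Any claim that something is new, unique, unknown or untested is made for them only; others in the source may bear on it.

Compound 3 `c1cc([C@H]2CC[C@]3(CC2)OOC2(O3)C3CC4CC(C3)CC2C4)ccc1OC1CCNCC1` carries a piperidin-4-yl group on an oxygen on an aromatic ring. In an ADME assay on microsomes from liver (Homo sapiens) for metabolic stability, read by LC-MS, tested at 1 uM (on this read-out lower numbers stand for slow clearance and higher numbers for fast clearance), compound 3 gives 15 mL.min-1.g-1, the lowest of the two plain numbers recorded. Compound 2 `CS(=O)(=O)N1CCN(CCCOc2ccc([C@H]3CC[C@]4(CC3)OOC3(O4)C4CC5CC(C4)CC3C5)cc2)CC1` gives 68 mL.min-1.g-1 in this assay, a clearly higher number. Compound 1 `CC(C)(CN)Oc1ccc([C@H]2CC[C@]3(CC2)OOC2(O3)C3CC4CC(C3)CC2C4)cc1` is reported only as a limit in this assay, at < 7 mL.min-1.g-1, so its true number is not known (the limit of < 7 mL.min-1.g-1 in this assay, at which 1 of the 3 values shown sits).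

The unmeasured compound 4 `CC(C)(N)CCOc1ccc([C@H]2CC[C@]3(CC2)OOC2(O3)C3CC4CC(C3)CC2C4)cc1` differs from compound 3 in one place: 3-amino-3-methylbutyl in place of piperidin-4-yl on an oxygen on an aromatic ring. Among the measured compounds shown here, the group that enters is an open-chain amine much like the one on compound 1, so the measured step that bears on this change is the one from compound 1 to compound 3, in which this assay moved an at least 2.1-fold higher number from compound 1 to compound 3 (0.33 log units; beyond the scatter). Going from compound 3 to compound 4 undoes most of that change, and the step is therefore expected to run in the opposite direction, giving a lower number that may again reach the limit of this assay; the expected step is a 1.9-fold lower number from compound 3 to compound 4 (0.27 log units; within the scatter). Compound 4 is accordingly estimated at 8 mL.min-1.g-1 in this assay, within a range from 4 mL.min-1.g-1 to 16 mL.min-1.g-1.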

Compound 4, intrinsic clearance in microsomes: < 7 mL.min-1.g-1
Compound 4 ended at the assay's limit; the forecaster's own chance of this, stated with the estimate: 35%; at least 1.1-fold (0.05 log units) between middle value and limit.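

The measured drop shows that compound 1's exact amine is not needed for a low number at this position: on the same oxygen on an aromatic ring, 3-amino-3-methylbutyl in place of piperidin-4-yl gives, in this assay, an at least 2.1-fold lower number from compound 3 to compound 4 (0.33 log units; beyond the scatter). Among the compounds shown here, the two groups are counted alike, with the same number of heavy atoms, so this pair isolates an open chain against a ring, though it is only one pair and sets no general rule. The larger step, an at least 9.7-fold lower number from compound 2 to compound 4 (0.98 log units; beyond the scatter), shows a wide spread of clearance among side chains on this core, and the low end of the range is now reached by two different open-chain amines: the limit of < 7 mL.min-1.g-1 in this assay, at which 2 of the 4 values shown sit.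

From the compounds shown here alone, the step between compound 1 and compound 4 cannot be read, as both values are limits, so the order of these two open-chain amines remains unknown. Also open, going by these compounds, is whether a chain that keeps the amine but loses its two methyl groups, or a carboxylic acid in place of the amine, would stay at this limit.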